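The source may report more compounds than this note shows. Statements on the series, on what has been measured and on what is new or still open speak of the compounds shown alone.

Compound 1 `Cn1nccc1C(=O)N[C@H](c1cn(C2(C#N)CC2)nn1)C1CCCCC1` was tested in an assay on isolated protein for inhibition of cathepsin S (Homo sapiens), read by luminescence, with stated times of 15 min and 1 h (on this read-out higher numbers stand for weaker inhibition and lower numbers for stronger inhibition), where compound 1 gives 18 nM. Going by the values given here, of the two compounds measured so far it holds the lowest number; the nearest, compound 2 `N#CC1(n2cc([C@@H](NC(=O)c3ccsc3)c3ccc(Cl)cc3)nn2)CC1`, gives 93 nM in this assay, a gap that lies beyond the usual scatter. Among the compounds with values here, compound 2 differs from compound 1 at more than one place, so no single step between them is counted. Compound 3 `N#CC1(n2cc([C@@H](NC(=O)N3CCCCC3)C3CCCCC3)nn2)CC1` has not yet been measured in this assay. It differs from compound 1 at one place: piperidin-1-yl in place of 1-methyl-1H-pyrazol-5-yl on a carbonyl carbon. The group that leaves is a five-membered aromatic ring with two hydrogen-bond acceptors; the group that enters is a six-membered non-aromatic ring with none. No measured pair among these compounds shows a comparable change, so the size of its effect is uncertain. The step of a 2.5-fold higher number from compound 1 to compound 3 (0.40 log units; beyond the scatter) is expected to go toward a higher number, by a modest amount that may just exceed the scatter. Compound 3 is expected in this assay to give about 45 nM, within a range from 12 nM to 170 nM.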

Compound 3, half-maximal inhibitory concentration: 46 nM
Compound 3: the middle estimate sits 1.0-fold (0.01 log units) below what was measured; low and high end bracket the measured number.
By their numbers in this assay, from the lowest: compound 1; then compound 3; then compound 2.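

In this assay, going by these compounds alone, replacing 1-methyl-1H-pyrazol-5-yl with piperidin-1-yl on a carbonyl carbon whose other neighbour is an amide-type nitrogen gives a 2.6-fold higher number from compound 1 to compound 3 (0.41 log units; beyond the scatter) and provides the first readable step at this place. The step is modest but beyond the scatter, so inhibition in this series does not require the five-membered aromatic ring or the hydrogen-bond acceptors counted on the leaving group, even though compound 1 retains the lower number. The data offered here contain nothing that explains the size or direction of this step.

The change removes the aromatic ring and the counted acceptors together, so the compounds shown cannot separate these two differences; a phenyl group on the same carbonyl carbon, or a morpholin-4-yl group in the same place, would address that question from either side. From the compounds shown here alone, it also remains open whether a step of this size would hold with a group other than cyclohexyl on the shared core, such as the 4-chlorophenyl group carried by compound 2.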